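Removing a Chloro Group from an Inactive Acylhydrazone

A few compounds are considered here, and "the series" means these few. Any claim that something is new, unique, unknown or untested is made for them only; others in the source may bear on it.

Compound 2 `COc1ccc(OC)c(/C=C/C(=O)N/N=C/c2ccc(Cl)cc2)c1` was tested in a functional assay on A498 cells (Homo sapiens) for antiproliferative activity, read by sulforhodamine B assay, with a stated time of 48 h; a lower number here means that less compound is tolerated, a higher number that more compound is tolerated. In this assay compound 2 gives > 100000 nM, which is a limit of the measurement and not a number. Compound 1 `COc1ccc(OC)c(/C=C/c2nnc(Nc3ccc(Cl)cc3)o2)c1` shows the same picture: in this assay compound 1 gives > 100000 nM, again a limit rather than a number. Compound 2 therefore stands where both measured values sit, at the limit of > 100000 nM in this assay, at which 2 of the 2 values shown sit. Compound 3 `COc1ccc(OC)c(/C=C/C(=O)N/N=C/c2ccccc2)c1` differs from compound 2 in one place: hydrogen in place of chloro on an aromatic carbon. Within the data shown here, no measured pair shows what this change does in this assay. With nothing to point another way, the step from compound 2 to compound 3 is expected to be none beyond the scatter, and compound 3 is expected most likely to be reported again as a limit. Compound 3 is estimated at 150000 nM, in the range 40000 nM to 500000 nM. The expected step is a step that the limit leaves unreadable from compound 2 to compound 3.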

Compound 3, concentration lethal to 50% of the cells: > 100000 nM
Compound 3 gave a limit, no number; the forecaster's own chance of this, stated with the estimate: 85%; the middle value does not contradict the limit.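

Compound 2 and compound 3 are both reported in this assay only as limits, not numbers, so no step can be read between them. The compounds shown leave open what the change from 4-chlorophenyl to phenyl does to the value in this assay.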